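The compounds below may be only part of what the source reports. "The series", "measured", "known", "first", "only" and "open" are said of these compounds alone.

Measured in a functional assay on HUVEC cells (Homo sapiens) for inhibition, read by crystal violet staining, with a stated time of 72 h; a higher number here means a weaker inhibitor of growth, a lower number a stronger inhibitor of growth:
Compound 1 `COc1ccc(-c2ccnn2-c2cc(OC)c(OC)c(OC)c2)cc1O`: 28 nM
Compound 2 `COc1ccc(-n2nccc2-c2cc(OC)c(OC)c(OC)c2)cc1O`: > 750 nM (a limit, not a number)
Compound 3 `COc1ccc(-c2cnn(C)c2-c2cc(OC)c(OC)c(OC)c2)cc1O`: 68 nM

Of the two compounds with true numbers, compound 3 has the higher, and its gap to compound 1 lies beyond the usual scatter of repeated measurements. Compound 2 is known only as the limit > 750 nM.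

Compound 4 `COc1ccc(-c2cnn(Cc3ccccc3)c2-c2cc(OC)c(OC)c(OC)c2)cc1O` differs from compound 3 in one place (phenyl in place of hydrogen on a saturated chain carbon bound to an aromatic nitrogen). Cut one bond further out, the same difference reads methyl to benzyl. Among the compounds with values here, no pair of measured compounds shows what such a change does in this assay, so this expectation rests on little. It starts from compound 3 at 68 nM and assumes a moderate loss of growth inhibition, beyond the scatter. There is also a real chance that only a limit is reported for compound 4. The expected change is an upward one, an estimated 3.7-fold higher number from compound 3 to compound 4 (0.57 log units; beyond the scatter). For compound 4 the estimated value is 250 nM, with an expected range from 70 nM to 900 nM.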

Compound 4, concentration for 50% growth inhibition: > 2500 nM
Compound 4 gave a limit, no number; the forecaster's own chance of this, stated with the estimate: 25%; middle value at least 10-fold (1.00 log units) away from the limit.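

In this assay, phenyl in place of hydrogen on a saturated chain carbon bound to an aromatic nitrogen, which turns methyl into benzyl, gives an at least 36-fold higher number from compound 3 to compound 4 (1.56 log units; beyond the scatter) and so a large loss of growth inhibition. Compound 3 shows that this place accepts methyl with 68 nM still measured as a true number, whereas the larger benzyl group does not keep that strength. The value for compound 4 is a limit, not a number, so the true size of the step could be greater still: the limit of > 2500 nM in this assay, at which 1 of the 4 values shown sits.

Only methyl and benzyl are shown at this place, so it remains open where between them the loss sets in, for instance with an ethyl group or a longer chain. Also open, from the compounds shown here alone, is whether a chain ending in an amine would fare any better than benzyl.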